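Removing a methylamino group: expected effect on solubility

The source may hold more compounds than are shown below. What is called first, only, known or untested is meant among the compounds shown, and "the series" means these compounds.

Compound 1 `COc1nc(N)nc2c1c(-c1ccc3oc(N)nc3c1)nn2C(C)C` in a physicochemical assay for solubility, read by HPLC, in phosphate buffer, measured as kinetic solubility, with a stated time of 24 h, at 20 degrees C, at pH 7.4, tested at 100 uM (a higher number here means a more soluble compound, a lower number a less soluble compound), gives < 1000 nM, which is a limit of the assay rather than a number. Compound 2 `CC(C)n1nc(-c2ccc3oc(N)nc3c2)c2c(N)nc(N)nc21` gives 88000 nM. Compound 3 `CNc1nc2c(c(-c3ccc4oc(N)nc4c3)nn2C(C)C)c(=O)[nH]1` gives < 1000 nM, again a limit of the assay. Compound 4 `CC(C)n1nc(-c2ccc3oc(N)nc3c2)c2c(=O)[nH]cnc21` has not yet been measured.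

Compound 3 therefore stands at the limit of < 1000 nM in this assay, at which 2 of the 3 values shown sit, so no number is known for it; only compound 2 has given a number. Going from compound 3 to compound 4 means (hydrogen in place of methylamino on an aromatic carbon). Among the measured compounds shown here, the only measured step, an at least 88-fold higher number from compound 1 to compound 2 (1.94 log units; beyond the scatter), concerns a different change on a different compound, so it bears only loosely on this one. With so little to go on, no step beyond the scatter is expected, and compound 3 is expected to stay near the limit. Compound 4 is estimated at 1000 nM, within 300 nM to 5000 nM, which is an expected step of a number no lower from compound 3 to compound 4 (the limit leaves the size open).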

Compound 4, solubility: 3000 nM
Compound 4: middle estimate off by 3.0-fold (0.48 log units), on the low side, and the stated range covers the measured number.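

On this aromatic carbon between two ring nitrogen atoms, hydrogen in place of methylamino gives an at least 3.0-fold higher number from compound 3 to compound 4 (0.47 log units; beyond the scatter) in this assay. This is the first step shown at this position, and it lifts the number clear of the limit, so compound 4 has a measured value. Going by these compounds, the value of compound 3 is only a limit, so the full size of the step stays unknown: the limit of < 1000 nM in this assay, at which 2 of the 4 values shown sit.

On these data alone, what a longer chain such as an ethylamino group, or a carboxylic acid, would give on this same carbon remains open.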